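Third methoxy on the anilino core: effect on inducible enzyme inhibition

This account rests on a few compounds, and the source may have more. Where it says the series, first, only, none or still open, it means among the compounds named here.

Measured compounds:
compound 1 `COc1ccc(N)c(C2=NN(C(=O)C3CC3)CC2)c1` — 19.9%
compound 2 `COc1cc(N)c(C2=NN(C(=O)C3CC3)CC2)cc1OC` — 25.2%

In an assay on isolated protein for inhibition of Nitric oxide synthase, inducible (Homo sapiens), with a stated time of 30 min, tested at 1 mM (on this read-out lower numbers stand for less inhibition and higher numbers for more inhibition at the one concentration tested (going by the name of the read-out)), compound 1 gives 19.9% and compound 2 gives 25.2%. Among the compounds with values here, the one step between them, a number 5.3 percentage points higher from compound 1 to compound 2 (within the scatter), is the sole guide in this small series. Compound 2 holds the higher of the two numbers, though its gap to compound 1 lies within the scatter, so no order can be read from it.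

Compound 3 `COc1cc(N)c(C2=NN(C(=O)C3CC3)CC2)c(OC)c1OC` has not yet been tested. It differs from compound 2 by methoxy in place of hydrogen on an aromatic carbon.

Within the data shown here, the only measured step that bears on this change is the earlier addition of a methoxy to an aromatic carbon, a number 5.3 percentage points higher from compound 1 to compound 2 (within the scatter), which did not rise above the scatter. A second such addition is therefore expected to move the number little: for the step from compound 2 to compound 3 an estimated a number 2.8 percentage points higher from compound 2 to compound 3 (within the scatter) is assumed, within the scatter. Compound 3 is accordingly expected to give about 28%, in a range from 12% to 44%.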

Compound 3, a percentage reported as inhibition, at one concentration (the size of the read-out at that concentration, not a potency): 30.1%
Estimate against measurement, compound 3: 2.1 percentage points below; the measured number falls inside the stated range.
By their numbers in this assay, from the lowest: compounds 1, 2 and 3 (each within the scatter of the next, the first and the last beyond it).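

In this assay, a methoxy in place of hydrogen on the aromatic carbon that is ortho to a large group and ortho to a methoxy group gives a number 4.9 percentage points higher from compound 2 to compound 3 (within the scatter). This position therefore accepts a methoxy without a step that can be told from the scatter, and the same holds for the earlier methoxy addition, a number 5.3 percentage points higher from compound 1 to compound 2 (within the scatter), so neither of the two single additions gives an order within its own pair. Nothing on hand explains where these numbers fall, and no cause can be assigned to the added methoxy at this position.

From the compounds shown here alone, whether a different group at this same aromatic carbon, such as a hydroxyl, a fluorine atom or the longer ethoxy chain, would produce a step beyond the scatter remains open. Also open is how the series would read in this assay if the amino group gave way to a carboxylic acid or a dimethylamino group, and whether any of these compounds would show a measurable potency rather than a size of inhibition at one concentration.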